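From a Limit Back to a Methylthiophene

The source may hold more compounds than are shown below. What is called first, only, known or untested is meant among the compounds shown, and "the series" means these compounds.

In a functional assay on DU-145 cells (Homo sapiens) for inhibition, read by trypan blue exclusion, with a stated time of 96 h (a higher number here means a weaker inhibitor of growth, a lower number a stronger inhibitor of growth), compound 2 `O=C(/C(=C\c1c(O)cc(O)cc1O)SCc1ccc(Cl)cc1)c1ccc(Cl)cc1` gives > 100000 nM, which is a limit and not a number. Under the same test, compound 1 `Cc1ccsc1/C=C(/SCc1ccc(Cl)cc1)C(=O)c1ccc(Cl)cc1` gives 50000 nM. Compound 3 `Cc1ccc(/C=C(/SCc2ccc(Cl)cc2)C(=O)c2ccc(Cl)cc2)s1` differs from compound 2 as follows: 5-methylthiophen-2-yl in place of 2,4,6-trihydroxyphenyl on a double-bonded chain carbon bound to a double-bonded chain carbon. That is, 5-methylthiophen-2-yl stands in place of 2,4,6-trihydroxyphenyl on a double-bonded chain carbon bound to a double-bonded chain carbon. Going by the values given here, the one measured step bearing on this is an at least 2.0-fold higher number from compound 1 to compound 2 (0.30 log units; that floor lies within the scatter), which put 2,4,6-trihydroxyphenyl in place of 3-methylthiophen-2-yl. Reversing that kind of change suggests a modest move towards a lower number. The expected step is an at least 2.5-fold lower number from compound 2 to compound 3 (0.39 log units; beyond the scatter). Compound 3 is estimated at 40000 nM, with an expected range of 12000 nM to 100000 nM.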

Compound 3, concentration for 50% growth inhibition: 50000 nM
Estimate against measurement, compound 3: 1.3-fold (0.10 log units) below, and the stated range covers the measured number.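

In this assay, 5-methylthiophen-2-yl and 3-methylthiophen-2-yl read alike on a double-bonded chain carbon bound to a double-bonded chain carbon: no change at the digits printed from compound 1 to compound 3 (within the scatter). Replacing 2,4,6-trihydroxyphenyl with 5-methylthiophen-2-yl gives an at least 2.0-fold lower number from compound 2 to compound 3 (0.30 log units; that floor lies within the scatter), so only a floor is known for this change. The true size of the step stays unknown because compound 2 has a limit and not a number: the limit of > 100000 nM in this assay, at which 1 of the 3 values shown sits.

Going by these compounds, whether an amine or a carboxylic acid at this place would shift the number from that of compound 3, 50000 nM, stays open. So does whether a thiophene without its methyl group would read the same.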